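Ethoxy to butoxy at the assay limit

This account rests on a few compounds, and the source may have more. Where it says the series, first, only, none or still open, it means among the compounds named here.

Measured in a functional assay on RAW264.7 cells (Mus musculus) for inhibition, with stated times of 2 h and 18 h (on this read-out lower numbers stand for stronger inhibition and higher numbers for weaker inhibition), where a sign before a value marks a limit of the assay:
- Compound 1 `COc1cc(/C=C/COC/C=C/c2cc(OC)c(O[C@@H]3O[C@H](CO)[C@@H](O)[C@H](O)[C@H]3O)c(OC)c2)cc(OC)c1O[C@@H]1O[C@H](CO)[C@@H](O)[C@H](O)[C@H]1O` gives > 100000 nM (a limit, not a number)
- Compound 2 `CCOC/C=C/c1cc(OC)c(O[C@@H]2O[C@H](CO)[C@@H](O)[C@H](O)[C@H]2O)c(OC)c1` gives > 100000 nM (a limit, not a number)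

Compound 2 has no number of its own in this assay and stands with compound 1 at the limit of > 100000 nM in this assay, at which 2 of the 2 values shown sit. Its result is therefore a limit, and how far it lies from any true value is not shown.

Compound 3 `CCCCOC/C=C/c1cc(OC)c(O[C@@H]2O[C@H](CO)[C@@H](O)[C@H](O)[C@H]2O)c(OC)c1` is the next compound to be tested. It differs from compound 2 by ethyl in place of hydrogen on a saturated chain carbon, two bonds along the chain from an oxygen on a saturated carbon, with ethyl in place of hydrogen on a saturated chain carbon, two bonds along the chain from an oxygen on a saturated carbon. Ethoxy thus becomes butoxy, and the rest of the structure is unchanged.

Going by the values given here, no measured step shows what such a change does in this assay. With only the limit of compound 2 as a guide, no step beyond the scatter is expected, in either direction. The expected a number no higher from compound 2 to compound 3 (the limit leaves the size open) reflects this. For compound 3 the estimate is 100000 nM, with an expected range from 40000 nM to 150000 nM.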

Compound 3, half-maximal inhibitory concentration: > 100000 nM
Compound 3: a limit, no number (the forecaster's own chance of this, stated with the estimate: 70%); the middle value lies on the limit itself.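

In this assay compound 3 gives > 100000 nM and this is a limit, not a number. Compound 2 also stands at a limit, so the change from ethoxy to butoxy between compound 2 and compound 3 cannot be read. The compounds shown leave open what inhibition, if any, these compounds reach, because all their results stop at the same point: the limit of > 100000 nM in this assay, at which 3 of the 3 values shown sit.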